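Cinnamamide series at the urotensin receptor: methoxy step

The compounds below may be only part of what the source reports. "The series", "measured", "known", "first", "only" and "open" are said of these compounds alone.

Measured so far in a functional assay on NIH3T3 cells for agonist activity at Urotensin-2 receptor (Homo sapiens), with a stated time of 5 days; a lower number here means that less compound is needed, a higher number that more compound is needed for the effect:
compound 1, `COc1ccc(/C=C/C(=O)NC(CCN(C)C)c2ccc(C)cc2)cc1`, gives 2000 nM
compound 2, `CN(C)CCC(NC(=O)/C=C/c1ccccc1)c1ccc2ccccc2c1`, gives 589 nM
compound 3, `Cc1ccc(C(CCN(C)C)NC(=O)/C=C/c2ccccc2)cc1`, gives 1550 nM

Compound 2 has the lowest number of the three; its gaps to compound 3 and to compound 1 are both beyond the scatter. The difference between the cores of compound 2 and compound 3 is not broken down here.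

One change has been measured once: methoxy in place of hydrogen on an aromatic carbon, giving a 1.3-fold higher number from compound 3 to compound 1 (0.11 log units; within the scatter). The same change is now applied to compound 2, yielding compound 4, `COc1ccc(/C=C/C(=O)NC(CCN(C)C)c2ccc3ccccc3c2)cc1`: methoxy in place of hydrogen on an aromatic carbon. The place lines read the same word for word, so this is the same change on a different core.

Resting on the measured step from compound 3 to compound 1, a similarly small shift is expected from compound 2 to compound 4, roughly a 1.3-fold higher number from compound 2 to compound 4 (0.10 log units; within the scatter) in this assay. Compound 4 is therefore estimated at 750 nM, with a plausible range from 350 nM to 1600 nM, on the strength of a single prior step only.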

Compound 4, half-maximal effective concentration: 380 nM
Beside the measured number, compound 4's estimate is 2.0-fold (0.30 log units) above it; the measured number falls inside the stated range.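

In this assay, methoxy in place of hydrogen on an aromatic carbon gives a 1.6-fold lower number from compound 2 to compound 4 (0.19 log units; within the scatter). Set beside the earlier step, the result on the two cores cannot be told apart: the same change on two cores in this assay, a 1.3-fold higher number (0.11 log units; within the scatter) from compound 3 to compound 1 and a 1.6-fold lower number (0.19 log units; within the scatter) from compound 2 to compound 4, 2.0-fold (0.30 log units) apart, within the scatter of two such steps. The change, phenyl to 4-methoxyphenyl, therefore carries from one core to the other with no step beyond the scatter on either, but two steps are a thin basis, give no firm direction, and do not show how the change would behave on any further core or at another place on the ring.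

The compounds shown carry only hydrogen or methoxy at this place, so it remains open how a fluorine, a hydroxyl, an amine or a carboxylic acid there would read in this assay. Also open, as far as these compounds go, is whether a longer alkoxy chain in place of methoxy would give a step beyond the scatter on either core.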